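Removing one trifluoromethyl from a diaryl urea pyrazole

The compounds below may be only part of what the source reports. "The series", "measured", "known", "first", "only" and "open" are said of these compounds alone.

Measured compounds:
compound 1 `O=C(Nc1cccc(-n2cc(-c3ccncc3)c(-c3cc(O)cc(Cl)c3)n2)c1)Nc1ccc(Cl)c(C(F)(F)F)c1`: 91%
compound 2 `O=C(Nc1cccc(-n2cc(-c3ccncc3)c(-c3cc(O)cc(Cl)c3)n2)c1)Nc1ccc(Cl)c(Cl)c1`: 106%
compound 3 `COc1cc(Cl)cc(-c2nn(-c3cccc(NC(=O)Nc4cc(C(F)(F)F)cc(C(F)(F)F)c4)c3)cc2-c2ccncc2)c1`: 96%

All three numbers come from a functional assay on T47D cells (Homo sapiens) for inhibition, read by sulforhodamine B assay, with a stated time of 48 h, tested at 0.01 uM; a higher number here means a weaker effect of the compound at the concentration tested, a lower number a stronger effect. Compound 3 stands second highest of the three; its value and that of compound 1 lie within the scatter of each other, as do its value and that of compound 2. Among the compounds with values here, the only step between measured compounds is a number 15 percentage points higher from compound 1 to compound 2 (beyond the scatter), a modest rise. Compound 4 `COc1cc(Cl)cc(-c2nn(-c3cccc(NC(=O)Nc4cccc(C(F)(F)F)c4)c3)cc2-c2ccncc2)c1` is unmeasured and differs from compound 3 by hydrogen in place of trifluoromethyl on an aromatic carbon. Within the data shown here, no measured step removes a trifluoromethyl entirely, so the step from compound 1 to compound 2 bears on it only loosely. With every value near full activity in this assay, the author expects a number 1 percentage points higher from compound 3 to compound 4 (within the scatter), no change beyond the scatter, and estimates for compound 4 a value of 97% with a range from 85% to 110%.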

Compound 4, a percentage reported as activity, at one concentration (the size of the read-out at that concentration, not a potency): 97%
For compound 4 middle estimate and measured number coincide at the digits printed, within the range that was stated.
By their numbers in this assay, from the lowest: compounds 1, 3, 4 and 2 (each within the scatter of the next, the first and the last beyond it).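

Hydrogen in place of trifluoromethyl gives, in this assay, a number 1 percentage points higher from compound 3 to compound 4 (within the scatter), the first step here that removes the group outright rather than exchanging it for chloro. With compound 4 keeping its other trifluoromethyl, the second one is thus not needed to hold this read-out where it stands at this one concentration. Nothing measured here explains this result.

As far as these compounds go, whether removing the remaining trifluoromethyl would also leave the read-out unmoved stays open. So does the outcome of an amine or a carboxylic acid at this place.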